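Aryl exchange on a shared core against A549 cells

This account rests on a few compounds, and the source may have more. Where it says the series, first, only, none or still open, it means among the compounds named here.

Measured so far:
compound 1, `Brc1cn2ccnc2c(-c2ccc3ncn(C4CCCCC4)c3c2)n1`, giving 9.36%
compound 2, `Brc1ccc(-c2cn3ccnc3c(-c3ccc4ncn(C5CCCCC5)c4c3)n2)cc1`, giving 15.3%

In a functional assay on A549 cells (Homo sapiens) for inhibition, read by sulforhodamine B assay, with a stated time of 48 h, tested at 10 uM (a higher number here means more inhibition at the concentration tested (going by the name of the read-out), a lower number less inhibition), compound 2 stands highest of the two numbers, with compound 1 nearest: a number 5.9 percentage points higher from compound 1 to compound 2 (within the scatter). Compound 3, `Fc1ccccc1-c1cn2ccnc2c(-c2ccc3ncn(C4CCCCC4)c3c2)n1`, is not yet measured. It differs from compound 2 in one place: 2-fluorophenyl in place of 4-bromophenyl on an aromatic carbon.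

Within the data shown here, only one measured step exists, and it concerns a different exchange, bromo for 4-bromophenyl, at the same site; that step was small and within the scatter. Nothing measured bears directly on exchanging one aryl ring for another. The two numbers seen are low and close together, so compound 3 is expected to give a similar low number, with no step beyond the scatter: a number 2.3 percentage points lower from compound 2 to compound 3 (within the scatter). For compound 3 the estimate in this assay is 13%, with a range from 0% to 30%.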

Compound 3, a percentage reported as inhibition, at one concentration (the size of the read-out at that concentration, not a potency): 9.1%
Estimate against measurement, compound 3: 3.9 percentage points above; the range from low to high includes it.
By their numbers in this assay, from the lowest: compounds 3, 1 and 2 (each within the scatter of the next).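

Among these compounds, this is the first exchange of one aryl ring for another at this position, on the aromatic carbon next to the ring nitrogen. In this assay, 2-fluorophenyl in place of 4-bromophenyl gives a number 6.2 percentage points lower from compound 2 to compound 3 (within the scatter) and 2-fluorophenyl in place of bromo gives a number 0.3 percentage points lower from compound 1 to compound 3 (within the scatter) so bromo and the two aryl groups shown cannot be told apart here, whichever pair is compared. No measurement available offers an explanation for these numbers.

The two aryl groups differ in both the halogen and where it sits, so the compounds shown do not separate these two changes, and plain phenyl or 4-fluorophenyl would be needed to do so. Going by these compounds, it also remains open whether a phenyl ring carrying an amine or a carboxylic acid at this position would stand clear of these three compounds.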